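Amide-nitrogen aryl change in the HT-29 series

This account rests on a few compounds, and the source may have more. Where it says the series, first, only, none or still open, it means among the compounds named here.

Compound 1 `Cc1ccc(NC(=O)CN2CCN(c3nnc(Cc4ccncc4)c4ccccc34)CC2)c(C)c1`: 1930 nM
Compound 2 `O=C(CN1CCN(c2nnc(Cc3ccccc3)c3ccccc23)CC1)Nc1ccc(F)c(C(F)(F)F)c1`: 4590 nM
Compound 3 `Cc1cccc(Cl)c1NC(=O)CN1CCN(c2nnc(Cc3ccccc3)c3ccccc23)CC1`: 53600 nM

In a functional assay on HT-29 cells (Homo sapiens) for cytotoxicity, read by MTT assay, with a stated time of 72 h (on this read-out lower numbers stand for stronger inhibition and higher numbers for weaker inhibition), compound 1 has the lowest number of the three. Unmeasured compound 4 `O=C(CN1CCN(c2nnc(Cc3ccncc3)c3ccccc23)CC1)Nc1cc(C(F)(F)F)ccc1Cl` differs from it as follows: 2-chloro-5-(trifluoromethyl)phenyl in place of 2,4-dimethylphenyl on an amide-type nitrogen. For the measured compounds named here, the one measured step at this place, a 12-fold higher number from compound 2 to compound 3 (1.07 log units; beyond the scatter), is large, so the aryl group can matter here. It involves different groups, however, and gives only a scale. Compound 4 carries a chloro group like compound 3 (53600 nM) and a trifluoromethyl group like compound 2 (4590 nM). The expected change is upward and smaller than that step: a 2.6-fold higher number from compound 1 to compound 4 (0.41 log units; beyond the scatter). For compound 4 the estimated value is 5000 nM, with an expected range of 1500 nM to 25000 nM.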

Compound 4, half-maximal inhibitory concentration: 4810 nM
Beside the measured number, compound 4's estimate is 1.0-fold (0.02 log units) above it; the measured number falls inside the stated range.
By their numbers in this assay, from the lowest: compound 1; then compounds 2 and 4 (each within the scatter of the next); then compound 3.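

With the core of compound 1 held fixed, the aryl group on the amide-type nitrogen still moves the number in this assay. Replacing 2,4-dimethylphenyl with 2-chloro-5-(trifluoromethyl)phenyl gives a 2.5-fold higher number from compound 1 to compound 4 (0.40 log units; beyond the scatter) and is a modest step, so this position now has a reading within a single core. No measured evidence bears on what lies behind this step.

Open, as far as these compounds go, is whether the chloro or the trifluoromethyl group accounts for the step. Also open, from the compounds shown here alone, is how an amine or a carboxylic acid on this aryl ring would read.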